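The source may report more compounds than this note shows. Statements on the series, on what has been measured and on what is new or still open speak of the compounds shown alone.

Three compounds have numbers in a functional assay on Raji cells (Homo sapiens) for cytotoxicity, read by MTT assay, with a stated time of 48 h; a higher number here means a weaker inhibitor, a lower number a stronger inhibitor. Compound 1 `Cc1ccc(Cn2c(/C=C3\SC(=S)N(CC(=O)O)C3=O)nc3ccc(Cl)cc32)cc1` gives 2790 nM, compound 2 `Cc1ccc(Cn2c(/C=C3\SC(=S)NC3=O)nc3ccccc32)cc1` gives 4480 nM, and compound 3 `O=C(O)CN1C(=O)/C(=C/c2nc3ccc(Cl)cc3n2Cc2ccccc2F)SC1=S` gives 8870 nM. The difference between the cores of compound 1 and compound 2 is not broken down here; their two numbers lie within the scatter of one another. Compound 3 differs from compound 1 by the change (2-fluorophenyl in place of 4-methylphenyl on a saturated chain carbon bound to an aromatic nitrogen), and that change made the step of a 3.2-fold higher number from compound 1 to compound 3 (0.50 log units; beyond the scatter). Compound 4 `O=C1NC(=S)S/C1=C\c1nc2ccccc2n1Cc1ccccc1F` carries the same change on the core of compound 2, (2-fluorophenyl in place of 4-methylphenyl on a saturated chain carbon bound to an aromatic nitrogen). Going by the values given here, compound 4 is expected to show a step of a 2.9-fold higher number from compound 2 to compound 4 (0.46 log units; beyond the scatter) in this assay, of the same order as the earlier one, resting only on the single step of a 3.2-fold higher number from compound 1 to compound 3 (0.50 log units; beyond the scatter), so the range is kept wide. For compound 4 the estimate in this assay is 13000 nM, between 5500 nM and 30000 nM.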

Compound 4, half-maximal inhibitory concentration: 25500 nM
Beside the measured number, compound 4's estimate is 2.0-fold (0.29 log units) below it; the measured number falls inside the stated range.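

In this assay the change to 2-fluorophenyl from 4-methylphenyl again raises the number, giving a 5.7-fold higher number from compound 2 to compound 4 (0.76 log units; beyond the scatter) on the second core. The change carries in the same direction on both cores, and the two steps cannot be told apart in size: the same change on two cores in this assay, a 3.2-fold higher number (0.50 log units; beyond the scatter) from compound 1 to compound 3 and a 5.7-fold higher number (0.76 log units; beyond the scatter) from compound 2 to compound 4, 1.8-fold (0.25 log units) apart, within the scatter of two such steps. This rests on two pairs only, so it sets no rule for the wider series, and it does not show what the differences between the two cores contribute on their own.

The separate roles of the carboxylic acid chain and the chlorine remain open, as no pair shown isolates either one. Also open, on these data alone, is how an unsubstituted phenyl or a longer chain ending in an amine would behave at this place.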